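A few compounds are considered here, and "the series" means these few. Any claim that something is new, unique, unknown or untested is made for them only; others in the source may bear on it.

Three measured compounds set the frame. Compound 1 `Cc1sc2nc(NC(=O)CCCc3ccccc3)sc(=O)c2c1C` gives 9.8 nM in an in vitro assay on cells for inhibition of Amine oxidase [flavin-containing] B (Homo sapiens), read by fluorescence and Amplex Red, with stated times of 30 min and 45 min; on this read-out higher numbers stand for weaker inhibition and lower numbers for stronger inhibition. Compound 2 `COc1cccc(C#CC(=O)Nc2nc3ccccc3c(=O)s2)c1` gives 43.7 nM in this assay, and compound 3 `COc1cccc(/C=C/CC(=O)Nc2nc3ccccc3c(=O)s2)c1` gives 238 nM in this assay. Compound 3 stands at the highest number of the three: compound 2, its nearest neighbour, sits at a lower number by more than the usual scatter, and compound 1 sits lower still, further beyond the scatter. Going by the values given here, no step between any two of these measured compounds is computed, so only their values are set side by side here.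

Compound 4 `O=C(C/C=C/c1ccccc1)Nc1nc2ccccc2c(=O)s1` is not yet measured. It differs from compound 3 by hydrogen in place of methoxy on an aromatic carbon. Among the compounds with values here, no measured pair in this set isolates that change, so there is no step to lean on, and nothing in the three values speaks for a large move in either direction. The step is expected to be small, a 1.1-fold higher number from compound 3 to compound 4 (0.02 log units; within the scatter), with no direction that would clearly exceed the scatter. Compound 4 is estimated at 250 nM in this assay, with a range from 80 nM to 800 nM.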

Compound 4, half-maximal inhibitory concentration: 39.8 nM
The estimate for compound 4 lay 6.3-fold (0.80 log units) above the measured number, outside the stated range (below it).
By their numbers in this assay, from the lowest: compound 1; then compounds 4 and 2 (each within the scatter of the next); then compound 3.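

Going by these compounds alone, the change from 3-methoxyphenyl to phenyl gives a 6.0-fold lower number from compound 3 to compound 4 (0.78 log units; beyond the scatter) in this assay, and this is the first step that can be read across a single place. The aromatic carbon meta to a large group therefore matters to the read-out on this chain: methoxy there is not interchangeable with hydrogen, and of this pair the compound carrying hydrogen gives the stronger inhibition. The measured data offer no explanation for the size or direction of this step.

A single pair cannot show whether any group at this place would raise the number or whether the result is particular to methoxy, so an amine, a hydroxyl group, a fluorine atom or a carboxylic acid at the same aromatic carbon would separate those two readings. On these data alone, it also remains open whether hydrogen in place of methoxy gives a step of similar size on the chain of compound 2, where the same methoxy group stands on the aromatic ring.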